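Methylphenyl isomers among the triazolyl esters

A few compounds are considered here, and "the series" means these few. Any claim that something is new, unique, unknown or untested is made for them only; others in the source may bear on it.

In a functional assay on DU-145 cells (Homo sapiens) for antiproliferative activity, read by MTT assay, with a stated time of 48 h (a higher number here means a weaker inhibitor, a lower number a stronger inhibitor), compound 1 `C#CCOC(=O)/C(C)=C/CC/C(C)=C/CC/C(C)=C/CC[C@@H]1[C@@]2(C)CCC(=O)C(C)(C)[C@H]2CC[C@@]1(C)O` gives 46100 nM and compound 2 `C/C(=C\CC/C(C)=C/CC[C@@H]1[C@@]2(C)CCC(=O)C(C)(C)[C@H]2CC[C@@]1(C)O)CC/C=C(\C)C(=O)OCc1cn(-c2cccc(C)c2)nn1` gives 137000 nM. Compound 2 therefore holds the higher number of the pair and is the weaker inhibitor so far. Compound 3 `C/C(=C\CC/C(C)=C/CC[C@@H]1[C@@]2(C)CCC(=O)C(C)(C)[C@H]2CC[C@@]1(C)O)CC/C=C(\C)C(=O)OCc1cn(-c2ccccc2C)nn1` differs from it by 2-methylphenyl in place of 3-methylphenyl on an aromatic nitrogen. Going by the values given here, the only measured step is a 3.0-fold higher number from compound 1 to compound 2 (0.47 log units; beyond the scatter), modest but beyond the scatter. That step installs the whole 1-(3-methylphenyl)-1H-1,2,3-triazol-4-yl group in place of ethynyl, so it bears only loosely on this change. Among the compounds with values here, no measured pair isolates the place of the methyl. No shift beyond the scatter is therefore expected in this assay, and no direction is favoured. The expected step is a 1.1-fold lower number from compound 2 to compound 3 (0.06 log units; within the scatter). Compound 3 is estimated at 120000 nM, with an expected range of 60000 nM to 220000 nM.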

Compound 3, half-maximal inhibitory concentration: > 150000 nM
Compound 3: a limit, no number; the forecaster's own chance of this, stated with the estimate: 15%; middle value at least 1.2-fold (0.09 log units) away from the limit.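

Compound 3 carries a limit of the assay rather than a number: the limit of > 150000 nM in this assay, at which 1 of the 3 values shown sits. In this assay, 2-methylphenyl in place of 3-methylphenyl on the aromatic nitrogen reads as an at least 1.0-fold higher number from compound 2 to compound 3 (0.03 log units; that floor lies within the scatter), so this change brings no stronger inhibition, while its true size stays unresolved. Against the ethynyl ester, the 1-(2-methylphenyl)-1H-1,2,3-triazol-4-yl group gives an at least 3.2-fold higher number from compound 1 to compound 3 (0.51 log units; beyond the scatter), so both methylphenyl isomers shown now carry higher numbers than the ethynyl compound.

Still open, from the compounds shown here alone, is how far the true value of compound 3 lies from that of compound 2, which a limit cannot settle. Also open, going by these compounds, is whether an amine or a carboxylic acid on the phenyl ring, in place of the methyl, would bring a triazolyl ester to a lower number than compound 1.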